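The compounds below may be only part of what the source reports. "The series", "measured", "known", "first", "only" and "open" are said of these compounds alone.

Measured compounds:
Compound 1, `CCCCCCOc1ccc(-n2cnnc2CCCCC)cc1`; in a functional assay on the whole organism (strain C57B/6) with Mus musculus as the target, in the maximal electroshock model (a lower number here means that less compound is needed, a higher number that more compound is needed for the effect), compound 1 gives 32.8 mg/kg.
Compound 2, `CCCCCCCc1nncn1-c1ccc(OCCCCCC)cc1`; in this assay compound 2 reaches only the limit of the test, > 40 mg/kg.
Compound 3, `CCCCCCOc1ccc(-n2cnnc2-c2ccccc2)cc1`; in this assay compound 3 gives 19 mg/kg.

Compound 2 thus stands without a number in this assay; what is known is that it sits at the limit of > 40 mg/kg in this assay, at which 1 of the 3 values shown sits. Compound 4, `CCCCCCOc1ccc(-n2cnnc2CCc2ccccc2)cc1`, is not yet measured. It differs from compound 2 by phenyl in place of pentyl on a saturated chain carbon, two bonds along the chain from an aromatic carbon.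

Among the measured compounds shown here, two measured steps bear on this. Exchanging an alkyl chain on the core for phenyl gave a 1.7-fold lower number from compound 1 to compound 3 (0.24 log units; within the scatter) and an at least 2.1-fold lower number from compound 2 to compound 3 (0.32 log units; beyond the scatter); the second of these starts from the limit of compound 2 and is the closer comparison, since the chain removed there is also heptyl, whereas in compound 4 the ring enters on a saturated chain carbon, two bonds along the chain from an aromatic carbon, leaving a phenethyl rather than a bare phenyl. A lower number in this assay is therefore expected for compound 4, though of uncertain size, and with some chance that the test again reports only a limit. For compound 4 the expected step is an at least 1.5-fold lower number from compound 2 to compound 4 (0.18 log units; that floor lies within the scatter). The estimate for compound 4 is 26 mg/kg, within 12 mg/kg to 60 mg/kg.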

Compound 4, dose for half-maximal effect: 27.4 mg/kg
Compound 4: the middle estimate sits 1.1-fold (0.02 log units) below what was measured; low and high end bracket the measured number.
By their numbers in this assay, from the lowest: compounds 3, 4 and 1 (each within the scatter of the next). At a limit, above all of these: compound 2.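

In this assay, phenethyl in place of phenyl on an aromatic carbon gives a 1.4-fold higher number from compound 3 to compound 4 (0.16 log units; within the scatter), so at this position the data do not separate the ring carried on the chain from the ring set on the core. Phenyl in place of propyl on a saturated chain carbon, two bonds along the chain from an aromatic carbon, gives a 1.2-fold lower number from compound 1 to compound 4 (0.08 log units; within the scatter), so the phenethyl of compound 4 and the pentyl of compound 1 are not told apart either. Phenyl in place of pentyl at the same place gives an at least 1.4-fold lower number from compound 2 to compound 4 (0.16 log units; that floor lies within the scatter), and this is only a floor that does not clear the scatter, since compound 2 is a limit and not a number: the limit of > 40 mg/kg in this assay, at which 1 of the 4 values shown sits.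

Going by these compounds, whether a benzyl at this position, or an amine or carboxylic acid at the end of the chain, would move the number beyond the scatter stays open. All four compounds carry the same hexyloxy group, so the effect of a shorter chain or an amine in its place is also unknown.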